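Hydroxy for Fluoro on the Aryl Tail of Compound 1

The compounds below may be only part of what the source reports. "The series", "measured", "known", "first", "only" and "open" are said of these compounds alone.

Measured compounds:
compound 1, `C=C/C=C\[C@H](C)[C@H](OC(N)=O)[C@@H](C)[C@H](O)[C@@H](C)C/C(C)=C\[C@H](C)[C@@H](O)[C@@H](C)/C=C\CCc1ccc(C)c(F)c1`, 4000 nM
compound 2, `C=C/C=C\[C@H](C)[C@H](OC(N)=O)[C@@H](C)[C@H](O)[C@@H](C)C/C(C)=C\[C@H](C)[C@@H](O)[C@@H](C)/C=C\CCc1cccc(F)c1`, 650 nM
compound 3, `C=C/C=C\[C@H](C)[C@H](OC(N)=O)[C@@H](C)[C@H](O)[C@@H](C)C/C(C)=C\[C@H](C)[C@@H](O)[C@@H](C)/C=C\CCc1cccc(O)c1C`, 910 nM

In a functional assay on A549 cells (Homo sapiens) for cytotoxicity (on this read-out lower numbers stand for stronger inhibition and higher numbers for weaker inhibition), compound 1 gives the highest number of the three, with compound 3 nearest and compound 2 furthest from it. The step of a 6.2-fold lower number from compound 1 to compound 2 (0.79 log units; beyond the scatter) comes from hydrogen in place of methyl on an aromatic carbon. The step of a 4.4-fold lower number from compound 1 to compound 3 (0.64 log units; beyond the scatter) comes from 3-hydroxy-2-methylphenyl in place of 3-fluoro-4-methylphenyl. The step of a 1.4-fold higher number from compound 2 to compound 3 (0.15 log units; within the scatter) lies within the scatter.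

Compound 4, `C=C/C=C\[C@H](C)[C@H](OC(N)=O)[C@@H](C)[C@H](O)[C@@H](C)C/C(C)=C\[C@H](C)[C@@H](O)[C@@H](C)/C=C\CCc1ccc(C)c(O)c1`, differs from compound 1 by hydroxy in place of fluoro on an aromatic carbon. Within the data shown here, no measured step isolates this exchange alone. The step of a 4.4-fold lower number from compound 1 to compound 3 (0.64 log units; beyond the scatter) is the nearest guide, but it also moves the methyl group, so its size cannot be assigned to the hydroxy alone; the step of a 1.4-fold higher number from compound 2 to compound 3 (0.15 log units; within the scatter) shows that compound 2 and compound 3 sit together. A modest lowering of the number is therefore expected for compound 4, smaller than that of compound 3, and the expected step is a 2.7-fold lower number from compound 1 to compound 4 (0.43 log units; beyond the scatter). Compound 4 is estimated at 1500 nM, with a range from 500 nM to 4500 nM.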

Compound 4, half-maximal inhibitory concentration: 4000 nM
For compound 4 the middle estimate is 2.7-fold (0.43 log units) below the measured one; low and high end bracket the measured number.
By their numbers in this assay, from the lowest: compounds 2 and 3 (each within the scatter of the next); then compounds 1 and 4 (each within the scatter of the next).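

In this assay, hydroxy in place of fluoro, on an aromatic carbon ortho to a methyl group and meta to a large group, leaves the read-out where it stood (no change at the digits printed from compound 1 to compound 4 (within the scatter)), so this exchange, which brings in one hydrogen-bond donor and one acceptor, shows no measurable consequence on the 3-fluoro-4-methylphenyl tail. The lower number of compound 3 therefore cannot be credited to the hydroxy group alone: with the hydroxy group present in both, 3-hydroxy-4-methylphenyl in place of 3-hydroxy-2-methylphenyl gives a clear step (a 4.4-fold higher number from compound 3 to compound 4 (0.64 log units; beyond the scatter)), which points to where the methyl group sits as the feature that matters. The step from the 3-fluorophenyl tail (a 6.2-fold higher number from compound 2 to compound 4 (0.79 log units; beyond the scatter)) fits the same reading, since compounds 1 and 4, which both carry the 4-methyl group, sit together above compounds 2 and 3, and none of the four goes against this.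

From the compounds shown here alone, it remains open whether hydroxy and fluoro also match on a tail without the methyl group, as in 3-hydroxyphenyl, and whether a methoxy group or an amine at this place would behave the same way. Nothing available here gives a reason for these differences.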